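Swapping the benzyl methoxy for bromo in a sulfonamide series

The source may report more compounds than this note shows. Statements on the series, on what has been measured and on what is new or still open speak of the compounds shown alone.

For the measured compounds named here, compound 1 `COc1ccc(CN(c2cc(OC)c(OC)c(OC)c2)S(=O)(=O)c2ccc(C)cc2)cc1` gives 8220 nM in a functional assay on PC-3 cells (Homo sapiens) for inhibition, read by MTT assay, with a stated time of 48 h (a lower number here means a stronger inhibitor, a higher number a weaker inhibitor), the lowest of the three numbers measured so far. Compound 3 `COc1ccc(CN(c2cc(OC)c(OC)c(OC)c2)S(=O)(=O)c2c(C)cc(C)cc2C)cc1` gives 14800 nM, and the step of a 1.8-fold higher number from compound 1 to compound 3 (0.26 log units; within the scatter) stays within the scatter, so no order between these two can be claimed. Compound 2 `COc1ccc(CN(c2cc(OC)c(OC)c(OC)c2)S(=O)(=O)c2ccc(OC)c(OC)c2)cc1` gives 20100 nM, a step of a 2.4-fold higher number from compound 1 to compound 2 (0.39 log units; beyond the scatter) that lies beyond the scatter. Compound 4 `COc1cc(N(Cc2ccc(Br)cc2)S(=O)(=O)c2ccc(C)cc2)cc(OC)c1OC` differs from compound 1 by bromo in place of methoxy on an aromatic carbon. Going by the values given here, every measured step changes the aryl group on the sulfonyl sulfur and none touches the benzyl side, so no measured step bears directly on this change. Compound 4 is therefore expected to show a step of a 1.1-fold higher number from compound 1 to compound 4 (0.04 log units; within the scatter), not beyond the scatter. The estimated value of compound 4 is 9000 nM, with a range from 3500 nM to 25000 nM.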

Compound 4, half-maximal inhibitory concentration: 4680 nM
Compound 4: the middle estimate sits 1.9-fold (0.28 log units) above what was measured; the range from low to high includes it.
By their numbers in this assay, from the lowest: compounds 4, 1, 3 and 2 (each within the scatter of the next, the first and the last beyond it).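

In this assay, for the compounds shown here, the change from 4-methoxybenzyl to 4-bromobenzyl gives the first measured step on the benzyl side (a 1.8-fold lower number from compound 1 to compound 4 (0.24 log units; within the scatter)). This step stays within the scatter, so bromo, with no hydrogen-bond acceptor, can stand in this place without a measurable separation from methoxy, and no order between the two can be claimed. Nothing available explains this result. As far as these compounds go, whether an amine, a carboxylic acid or a longer chain at this position would stay within the scatter remains open. So does whether bromo behaves alike with the 3,4-dimethoxyphenyl or 2,4,6-trimethylphenyl group on the sulfonyl sulfur.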